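The source may hold more compounds than are shown below. What is called first, only, known or untested is meant among the compounds shown, and "the series" means these compounds.

Measured so far:

Compound 1, `O=c1[nH]c2ccccc2cc1/C=N/O`: in a functional assay, read by spectrophotometry, with a stated time of 1 h (on this read-out lower numbers stand for stronger inhibition and higher numbers for weaker inhibition), compound 1 gives 2010000 nM.
Compound 2, `Cc1ccc2[nH]c(=O)c(/C=N/O)cc2c1`: in this assay compound 2 gives 1980000 nM.
Compound 3, `Cc1ccc2[nH]c(=O)c(/C=N/Nc3ccc([N+](=O)[O-])cc3)cc2c1`: in this assay compound 3 gives 350000 nM.

Compound 3 gives the lowest number of the three, and its distance from compound 2 and from compound 1 is in each case beyond the scatter. Compound 2 and compound 1 differ in one place, (hydrogen in place of methyl on an aromatic carbon), and this step gave a 1.0-fold higher number from compound 2 to compound 1 (0.01 log units; within the scatter), so the two values carry no order between them.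

Compound 4, `O=c1[nH]c2ccccc2cc1/C=N/Nc1ccc([N+](=O)[O-])cc1`, is not yet measured in this assay. It differs from compound 3 by hydrogen in place of methyl on an aromatic carbon, the same change as from compound 2 to compound 1, at the same place. How the core of compound 3 differs from the core of compound 2 is not broken down here.

Because the earlier instance gave a 1.0-fold higher number from compound 2 to compound 1 (0.01 log units; within the scatter), the step from compound 3 to compound 4 is expected to be no change at the digits printed from compound 3 to compound 4 (within the scatter). Compound 4 is therefore estimated at 350000 nM, between 160000 nM and 760000 nM.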

Compound 4, half-maximal inhibitory concentration: 245000 nM
The estimate for compound 4 lay 1.4-fold (0.15 log units) above the measured number; the measured number falls inside the stated range.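

In this assay, hydrogen in place of methyl on the aromatic carbon gives a 1.4-fold lower number from compound 3 to compound 4 (0.15 log units; within the scatter), so this second instance of the change also stays within the scatter. Set side by side, the two instances do not differ: the same change on two cores in this assay, a 1.0-fold higher number (0.01 log units; within the scatter) from compound 2 to compound 1 and a 1.4-fold lower number (0.15 log units; within the scatter) from compound 3 to compound 4, 1.5-fold (0.16 log units) apart, within the scatter of two such steps

On these two cores, then, the change carries over as no readable shift in the number, but this rests on only two instances, both with the same change at the same place, and says nothing about other cores, other places on the ring or other assays. The compounds shown carry only methyl or hydrogen at this place, so it stays open whether a chlorine atom, a methoxy group or a longer alkyl chain there would move the number beyond the scatter. On these data alone, it also stays open how the number would respond to an amine or a carboxylic acid in place of the nitro group of compound 3 and compound 4.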